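Swapping the aryl group on a triazole: effect on cytotoxicity

The compounds below may be only part of what the source reports. "The series", "measured", "known", "first", "only" and "open" are said of these compounds alone.

Measured in a functional assay on MCF7 cells (Homo sapiens) for cytotoxicity, read by MTT assay, with a stated time of 48 h; on this read-out higher numbers stand for weaker inhibition and lower numbers for stronger inhibition:
compound 1 `COc1cc(OC)c(-n2cc(CO/N=C3\CC[C@]4(C)[C@@H](CC/C=C(\C)CC/C=C(\C)CCC=C(C)C)[C@](C)(O)CC[C@H]4C3(C)C)nn2)c(OC)c1` gives 14700 nM
compound 2 `CC(C)=CCC/C(C)=C/CC/C(C)=C/CC[C@@H]1[C@@]2(C)CC/C(=N\OCc3cn(-c4ccncc4)nn3)C(C)(C)[C@@H]2CC[C@@]1(C)O` gives 12600 nM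
compound 3 `COc1cc(OC)c(-n2cc(COc3ccc(/C=C4\C[C@]5(C)[C@@H](CC/C=C(\C)CC/C=C(\C)CCC=C(C)C)[C@](C)(O)CC[C@H]5C(C)(C)C4=O)cc3)nn2)c(OC)c1` gives 13500 nM

All three numbers lie close together, and the differences among them are within the usual scatter of this kind of measurement. Compound 4 `CC(C)=CCC/C(C)=C/CC/C(C)=C/CC[C@@H]1[C@@]2(C)C/C(=C\c3ccc(OCc4cn(-c5ccncc5)nn4)cc3)C(=O)C(C)(C)[C@@H]2CC[C@@]1(C)O` has not yet been measured. It differs from compound 3 in one place: pyridin-4-yl in place of 2,4,6-trimethoxyphenyl on an aromatic nitrogen. The same change links the two measured compounds 1 and 2: pyridin-4-yl in place of 2,4,6-trimethoxyphenyl on an aromatic nitrogen. The two place descriptions agree word for word, so this is the same change made on two different cores; how the core of compound 3 differs from the core of compound 1 is not broken down here. Where it has been measured, the change gave a 1.2-fold lower number from compound 1 to compound 2 (0.07 log units; within the scatter), a step that is within the scatter. Within the data shown here, the estimated step of a 1.1-fold lower number from compound 3 to compound 4 (0.05 log units; within the scatter) is expected to be of the same small size, because the only measured example, a 1.2-fold lower number from compound 1 to compound 2 (0.07 log units; within the scatter), barely moved the number. Compound 4 is therefore estimated at 12000 nM, with the expected range running from 6000 nM to 26000 nM.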

Compound 4, half-maximal inhibitory concentration: 37500 nM
Compound 4: the middle estimate sits 3.1-fold (0.49 log units) below what was measured, and the stated range ends below it.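

In this assay, putting pyridin-4-yl in place of 2,4,6-trimethoxyphenyl on an aromatic nitrogen gave a 2.8-fold higher number from compound 3 to compound 4 (0.44 log units; beyond the scatter), a modest weakening of inhibition on this core. Set beside the earlier step, the same swap does not carry over unchanged from one core to the other: the same change on two cores in this assay, a 1.2-fold lower number (0.07 log units; within the scatter) from compound 1 to compound 2 and a 2.8-fold higher number (0.44 log units; beyond the scatter) from compound 3 to compound 4, 3.2-fold (0.51 log units) apart, beyond the scatter of two such steps

So in this series the outcome of the swap depends on the core it is made on, and a result from one core is a poor guide to another; with only two pairs, however, this does not show which part of the core is responsible or what the swap would do on a third core.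

The compounds shown leave open whether this core dependence is particular to pyridin-4-yl or would also appear with other groups on that nitrogen, such as a plain phenyl or a benzyl group. They also leave open whether the two cores would diverge in the same way in other cell lines.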